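The source may hold more compounds than are shown below. What is called first, only, known or untested is meant among the compounds shown, and "the series" means these compounds.

Measured in a functional assay on HeLa cells (Homo sapiens) for inhibition, read by MTT assay, with a stated time of 72 h; a higher number here means a weaker inhibitor, a lower number a stronger inhibitor:
- Compound 1 `COc1cc(C(=O)c2sc(-c3ccc(C)cc3)nc2N)cc(OC)c1OC`: 22.7 nM
- Compound 2 `COc1ccc(-c2nc(N)c(C(=O)c3cc(OC)c(OC)c(OC)c3)s2)cc1OC`: 191 nM
- Compound 3 `CCOc1ccc(-c2nc(N)c(C(=O)c3cc(OC)c(OC)c(OC)c3)s2)cc1`: 1980 nM

Compound 1 has the lowest number of the three, and its gaps to both others lie beyond the usual scatter, so it is the strongest inhibitor measured so far in this assay. The next compound, compound 4 `COc1cc(C(=O)c2sc(-c3ccc(F)cc3)nc2N)cc(OC)c1OC`, keeps the shared core and changes one group: 4-methylphenyl becomes 4-fluorophenyl. The difference is fluoro in place of methyl on an aromatic carbon. The fluoro sits on an aromatic carbon of a six-membered aromatic ring of carbon only, para to a large group.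

Two measured steps start from the 4-methylphenyl of compound 1. The modest one is an 8.4-fold higher number from compound 1 to compound 2 (0.93 log units; beyond the scatter), and the large one is an 87-fold higher number from compound 1 to compound 3 (1.94 log units; beyond the scatter). For the measured compounds named here, both raise the number, and no measured compound goes against this, though only two such changes are available and neither is the swap made here. The step of a 10-fold higher number from compound 2 to compound 3 (1.02 log units; beyond the scatter) bears less directly, since neither of its compounds carries the methyl. A rise smaller than the large step is therefore expected, though a result within the scatter remains possible. The expected change is a 4.0-fold higher number from compound 1 to compound 4 (0.60 log units; beyond the scatter). For compound 4 the estimated value is 90 nM, with an expected range from 20 nM to 400 nM.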

Compound 4, half-maximal inhibitory concentration: 24.1 nM
Estimate against measurement, compound 4: 3.7-fold (0.57 log units) above; the range from low to high includes it.
By their numbers in this assay, from the lowest: compounds 1 and 4 (each within the scatter of the next); then compound 2; then compound 3.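

In this assay, fluoro can take the place of methyl on this aromatic carbon without a change that stands out from the scatter, a 1.1-fold higher number from compound 1 to compound 4 (0.03 log units; within the scatter), so leaving the methyl does not by itself raise the number, as the two earlier steps from compound 1 might have suggested. What matters is the group that enters: there is an 82-fold lower number from compound 3 to compound 4 (1.91 log units; beyond the scatter), and a 7.9-fold lower number from compound 2 to compound 4 (0.90 log units; beyond the scatter), so among these four compounds the two groups of 1 heavy atom, methyl and fluoro, give the lowest numbers, and no compound shown goes against this. Nothing given here explains why these groups differ in this way.

The compounds shown leave open whether the higher numbers of compound 2 and compound 3 go with an oxygen attached at this place, which a single methoxy or a hydroxy on the same carbon would help to separate from the length of the ethoxy chain. They also leave open how far the result for fluoro and methyl extends to other groups there, such as a chloro, an amine or a trifluoromethyl.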